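The compounds below may be only part of what the source reports. "The series", "measured", "known", "first", "only" and "open" are said of these compounds alone.

compound 1 `Cc1cc(C)c(S(=O)(=O)NCCN2CCC(C)CC2)c(C)c1` gives 1900 nM
compound 2 `COc1ccccc1-c1cccc(S(=O)(=O)N2CCC(N3CCC(C)CC3)CC2)c1` gives 21 nM
compound 3 `COc1ccccc1-c1ccc(S(=O)(=O)N2CCC(N3CCC(C)CC3)CC2)cc1` gives 26 nM

All three were read in a functional assay on DLD-1 cells (Homo sapiens) for antiproliferative activity, read by CellTiter-Glo, with a stated time of 72 h (on this read-out lower numbers stand for stronger inhibition and higher numbers for weaker inhibition), and there compound 2 stands level with compound 3 within the scatter, while compound 1 shows a far higher number, well beyond the scatter from compound 2.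

In compound 4 `CC1CCN(C2CCN(S(=O)(=O)c3cccc(-c4ccc5ccccc5c4)c3)CC2)CC1` naphthalen-2-yl takes the place of 2-methoxyphenyl on an aromatic carbon (naphthalen-2-yl in place of 2-methoxyphenyl on an aromatic carbon) and the rest is unchanged. Going by the values given here, no measured pair shows this change, so in this assay little or no step beyond the scatter is expected, with a slight lean toward weaker inhibition. The estimated step is a 1.7-fold higher number from compound 2 to compound 4 (0.22 log units; within the scatter) on this reasoning. Compound 4 is expected at 35 nM with an estimated range from 12 nM to 100 nM as its likely span.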

Compound 4, half-maximal inhibitory concentration: 2 nM
Compound 4: middle estimate off by 18-fold (1.24 log units), on the high side, outside the stated range (below it).
By their numbers in this assay, from the lowest: compound 4; then compounds 2 and 3 (each within the scatter of the next); then compound 1.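

In this assay, the group on this aromatic carbon, meta to a large group, proves to matter: naphthalen-2-yl in place of 2-methoxyphenyl gives an 11-fold lower number from compound 2 to compound 4 (1.02 log units; beyond the scatter), a step beyond the scatter. The change brings a second six-membered aromatic ring of carbon only and removes the hydrogen-bond acceptor of the leaving group, and no earlier pair had shown any change of this group. No evidence on hand explains the step.

The compounds shown leave open whether the added ring or the lost methoxy group carries the step. An unsubstituted phenyl or a quinolin-3-yl at this place would help to separate the two.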